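The compounds below may be only part of what the source reports. "The series", "measured", "known", "first", "only" and "open" are said of these compounds alone.

Compound 1 `CC1CCN(C2CCN(S(=O)(=O)c3cccc(Br)c3)CC2)CC1` gives 3.2 nM.
Compound 2 `CC1CCN(C2CCN(S(=O)(=O)c3cccc(-c4ccccc4F)c3)CC2)CC1` gives 10 nM.
Compound 3 `Cc1cc(C)cc(-c2cccc(S(=O)(=O)N3CCC(N4CCC(C)CC4)CC3)c2)c1` gives 41 nM.

All three numbers come from a functional assay on DLD-1 cells (Homo sapiens) for antiproliferative activity, read by CellTiter-Glo, with a stated time of 72 h; a higher number here means a weaker inhibitor, a lower number a stronger inhibitor. Compound 1 stands lowest of the three: the change to compound 2 raises the number a 3.1-fold higher number from compound 1 to compound 2 (0.49 log units; beyond the scatter), and the change to compound 3 raises it further a 13-fold higher number from compound 1 to compound 3 (1.11 log units; beyond the scatter). Compound 4 `CC1CCN(C2CCN(S(=O)(=O)c3cncc(Br)c3)CC2)CC1` differs from compound 1 in one place: 5-bromopyridin-3-yl in place of 3-bromophenyl on a sulfonyl sulfur. Among the compounds with values here, each measured step replaces the bromo group on an aromatic carbon, whereas here the ring itself changes and the bromine stays, so none of the measured steps bears directly on this change. Without a guide, the number for compound 4 is expected to stay close to that of compound 1, with a step of a 1.6-fold higher number from compound 1 to compound 4 (0.19 log units; within the scatter) within the scatter. The estimate for compound 4 is 5 nM, between 1.5 nM and 16 nM.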

Compound 4, half-maximal inhibitory concentration: > 5000 nM
Compound 4: a limit, no number; the forecaster's own chance of this, stated with the estimate: 2%; at least 1000-fold (3.00 log units) between middle value and limit.
By their numbers in this assay, from the lowest: compound 1; then compound 2; then compound 3. At a limit, above all of these: compound 4.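

Until now only the bromo group had changed, and every number stayed low. Compound 4 keeps the bromine and changes the ring on the sulfonyl sulfur instead, bringing in a ring nitrogen, and this gives an at least 1500-fold higher number from compound 1 to compound 4 (3.19 log units; beyond the scatter), far more than any replacement of the bromo group. For compound 4, this assay gives a limit and not a number: the limit of > 5000 nM in this assay, at which 1 of the 4 values shown sits.

As far as these compounds go, what remains open is whether a methoxy group or a chlorine in place of the bromo group would keep the low number of compound 1. From the compounds shown here alone, it is also open how a pyrimidine ring would behave in place of the 3-bromophenyl ring.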